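Benzyl in Place of Pentyl on the Carbamate

The source may report more compounds than this note shows. Statements on the series, on what has been measured and on what is new or still open speak of the compounds shown alone.

Three compounds share one core and differ only in the group on an oxygen next to a carbonyl group. Compound 1 `CCOC(=O)N1CCN(C(=O)c2nc(Nc3cc(C4CC4)[nH]n3)c3cc(Cl)ccc3n2)C[C@H]1C` gives 93.4% in an assay for inhibition of serine/threonine-protein kinase PAK 4 (Homo sapiens), read by FRET and Z'-LYTE, with a stated time of 60 min, tested at 50 uM, in the presence of a further agent that is not named here; on this read-out higher numbers stand for a stronger effect at the one concentration tested and lower numbers for a weaker effect. Compound 2 `C[C@@H]1CN(C(=O)c2nc(Nc3cc(C4CC4)[nH]n3)c3cc(Cl)ccc3n2)CCN1C(=O)OC(C)(C)C` gives 36.4% in this assay, and compound 3 `CCCCCOC(=O)N1CCN(C(=O)c2nc(Nc3cc(C4CC4)[nH]n3)c3cc(Cl)ccc3n2)C[C@H]1C` gives 32.7%. Compound 3 holds the lowest of the three numbers, nearest compound 2 and furthest from compound 1, though its gap to compound 2 is within the scatter. The measured steps were a number 57 percentage points lower from compound 1 to compound 2 (beyond the scatter) and a number 60.7 percentage points lower from compound 1 to compound 3 (beyond the scatter), while a number 3.7 percentage points lower from compound 2 to compound 3 (within the scatter). Compound 4 `C[C@@H]1CN(C(=O)c2nc(Nc3cc(C4CC4)[nH]n3)c3cc(Cl)ccc3n2)CCN1C(=O)OCc1ccccc1` differs from compound 3 by phenyl in place of butyl on a saturated chain carbon bound to an oxygen next to a carbonyl group. Both steps away from ethyl were large, yet the exchange of tert-butyl for pentyl changed little. Compound 4 is expected to remain near compound 3, with a number 2.3 percentage points higher from compound 3 to compound 4 (within the scatter) within the scatter, because a number 3.7 percentage points lower from compound 2 to compound 3 (within the scatter) shows that swapping one such group for another left the number much the same. Compound 4 is therefore estimated at 35%, with a range from 15% to 60%.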

Compound 4, a percentage reported as inhibition, at one concentration (the size of the read-out at that concentration, not a potency): 96%
Compound 4: middle estimate off by 61 percentage points, on the low side; measured number above the stated range.
By their numbers in this assay, from the lowest: compounds 3 and 2 (each within the scatter of the next); then compounds 1 and 4 (each within the scatter of the next).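

In this assay, among the compounds shown here, the earlier compounds could be read as showing that any group in place of ethyl on this oxygen lowers the number, and benzyl goes against that reading: the result is a number 63.3 percentage points higher from compound 3 to compound 4 (beyond the scatter) and a number 59.6 percentage points higher from compound 2 to compound 4 (beyond the scatter) while also a number 2.6 percentage points higher from compound 1 to compound 4 (within the scatter) so that benzyl and ethyl cannot be told apart here. The response at this position therefore does not follow the count of heavy atoms alone, since phenyl has more of them than the butyl it replaces and yet the number recovers. Nothing in the data shown explains this split between the two pairs of compounds.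

The compounds shown leave open where along the chain the number falls, between ethyl and pentyl, as a propyl or butyl chain would show. They also leave open whether the phenyl ring is needed, which a cyclohexylmethyl, pyridylmethyl or phenethyl group on the same oxygen would test.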